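From 2-fluorophenyl to 4-fluorophenyl: notes on compound 4

A few compounds are considered here, and "the series" means these few. Any claim that something is new, unique, unknown or untested is made for them only; others in the source may bear on it.

- compound 1 `Cn1cc([N+](=O)[O-])cc1C(=O)NNC(=S)Nc1ccccc1F`: 293000 nM
- compound 2 `O=C(NNC(=O)c1cc([N+](=O)[O-])c[nH]1)Nc1ccc([N+](=O)[O-])cc1`: 211000 nM
- compound 3 `COc1cc(NC(=S)NNC(=O)c2cc([N+](=O)[O-])c[nH]2)cc(OC)c1OC`: 328000 nM

In an ADME assay on Vero cells (Chlorocebus sabaeus) for cytotoxicity, read by MTT assay, with a stated time of 72 h (a lower number here means a stronger inhibitor, a higher number a weaker inhibitor), compound 1 stands level with compound 2 and compound 3, since all three values lie within the scatter of each other. The next compound to be measured is compound 4 `Cn1cc([N+](=O)[O-])cc1C(=O)NNC(=S)Nc1ccc(F)cc1`, which differs from compound 1 by 4-fluorophenyl in place of 2-fluorophenyl on an amide-type nitrogen. For the measured compounds named here, no measured pair differing in one place is available to size this change. The expectation in this assay therefore rests on compound 1 at 293000 nM, with no step beyond the scatter. The estimated step is a 1.0-fold lower number from compound 1 to compound 4 (0.02 log units; within the scatter). For compound 4 the expected value is 280000 nM, within an estimated range of 150000 nM to 500000 nM.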

Compound 4, half-maximal inhibitory concentration: 662000 nM
Beside the measured number, compound 4's estimate is 2.4-fold (0.37 log units) below it, outside the stated range (above it).
By their numbers in this assay, from the lowest: compounds 2, 1, 3 and 4 (each within the scatter of the next, the first and the last beyond it).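

In this assay the change of 2-fluorophenyl to 4-fluorophenyl on the amide-type nitrogen gives (a 2.3-fold higher number from compound 1 to compound 4 (0.35 log units; beyond the scatter)). For the compounds shown here, this is the first one-place pair, and it shows that the read-out at this position responds to where the fluorine sits, even though the two groups have the same atoms. Nothing available bears on the reason for this step.

From the compounds shown here alone, it remains open whether a plain phenyl or a 4-chlorophenyl on the same nitrogen would read closer to compound 1 or to compound 4. Going by these compounds, it is also open whether the same change would carry over to the core of compound 3.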